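Series notes: amide for sulfonamide on compound 3

The source may hold more compounds than are shown below. What is called first, only, known or untested is meant among the compounds shown, and "the series" means these compounds.

Measured compounds:
Compound 1, `CCCN(CCC)S(=O)(=O)c1ccc(S(=O)(=O)N2CCC[C@@H](C(=O)OCC)C2)cc1`; in a functional assay on BXPC-3 cells (Homo sapiens) for inhibition, read by MTT assay, with a stated time of 7 days (on this read-out higher numbers stand for weaker inhibition and lower numbers for stronger inhibition), compound 1 gives 2500 nM.
Compound 2, `CCOC(=O)[C@@H]1CCCN(S(=O)(=O)c2ccc(S(=O)(=O)N3CCCCC3)cc2)C1`; in this assay compound 2 gives 3300 nM.
Compound 3, `CCOC(=O)[C@@H]1CCCN(S(=O)(=O)c2ccc(S(=O)(=O)N(C)C)cc2)C1`; in this assay compound 3 gives 1000 nM.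

Compound 3 stands lowest of the three numbers; its nearest neighbour is compound 1 and its furthest is compound 2, and both gaps are beyond the scatter. Compound 4, `CCOC(=O)[C@@H]1CCCN(S(=O)(=O)c2ccc(C(=O)N(CC)CC)cc2)C1`, is not yet measured. It differs from compound 3 in one place: diethylcarbamoyl in place of dimethylsulfamoyl on an aromatic carbon.

Among the compounds with values here, two measured steps bear on the size of the group carried on that sulfonyl sulfur: a 2.5-fold lower number from compound 1 to compound 3 (0.40 log units; beyond the scatter) and a 3.3-fold lower number from compound 2 to compound 3 (0.52 log units; beyond the scatter), both modest and both going to a lower number as the group shrinks to dimethylamino. A third step lies within the scatter: a 1.3-fold higher number from compound 1 to compound 2 (0.12 log units; within the scatter). Nothing measured covers the exchange of a sulfonyl for a carbonyl; only the change from dimethyl to diethyl on the nitrogen has an analogue, and growth in that direction gave higher numbers. A modest rise in this assay is therefore expected, a 2.0-fold higher number from compound 3 to compound 4 (0.30 log units; within the scatter), with wide uncertainty. Compound 4 is estimated at 2000 nM, range 700 nM to 6000 nM.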

Compound 4, half-maximal inhibitory concentration: 640 nM
The estimate for compound 4 lay 3.1-fold (0.49 log units) above the measured number; measured number outside the range, below it.
By their numbers in this assay, from the lowest: compounds 4 and 3 (each within the scatter of the next); then compounds 1 and 2 (each within the scatter of the next).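

In this assay, the carbonyl-linked diethylcarbamoyl on this aromatic carbon, para to a large group, is not separated from the dimethylsulfamoyl it replaces, with a 1.6-fold lower number from compound 3 to compound 4 (0.19 log units; within the scatter), so a sulfonyl at this position is not required for a number in this range. Against the larger sulfonyl-linked groups, the same diethylcarbamoyl gives a 5.2-fold lower number from compound 2 to compound 4 (0.71 log units; beyond the scatter) and a 3.9-fold lower number from compound 1 to compound 4 (0.59 log units; beyond the scatter), which shows that the earlier link between a smaller group and a lower number holds only among compound 1, compound 2 and compound 3, while compound 4 goes against it by carrying more heavy atoms than the dimethylsulfamoyl yet staying level with it. No measurement shown offers an explanation for these numbers.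

The exchange in compound 4 alters both the linking group and the alkyl groups on nitrogen, so the contribution of each stays unresolved; a dimethylcarbamoyl, a dipropylcarbamoyl or a piperidine-1-carbonyl group would separate the two. Also open, going by these compounds, is whether a primary amide or a carboxylic acid at this position would keep a number in the same range.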